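The source may hold more compounds than are shown below. What is called first, only, known or untested is meant among the compounds shown, and "the series" means these compounds.

Measured so far, in an ADME assay on BJ cells (Homo sapiens) for cytotoxicity, with a stated time of 72 h; a higher number here means that more compound is needed for the effect, a lower number that less compound is needed:

compound 1, `Cc1cc(NC(=O)Nc2ccc(F)c(F)c2)c2ccccc2n1`, gives > 25000 nM, which is a limit of the assay and not a number.
compound 2, `Cc1cc(NC(=O)Nc2ccc(N(C)C)cc2)c2ccccc2n1`, gives > 25000 nM, again a limit.
compound 3, `Cc1cc(NC(=O)Nc2ccccc2OC(F)(F)F)c2ccccc2n1`, gives > 25000 nM, again a limit.

Compound 1 therefore stands at no fixed point; it shares (the limit of > 25000 nM in this assay, at which 3 of the 3 values shown sit). All three measured compounds sit at that limit, so none of them can be placed above or below the others in this assay. Compound 4, `Cc1cc(NC(=O)Nc2cccc(F)c2)c2ccccc2n1`, has not yet been measured. It differs from compound 1 by hydrogen in place of fluoro on an aromatic carbon. Going by the values given here, no step between two measured compounds is known, so there is no measured size of step to lean on. Because compound 1 and the other measured compounds all sit at the limit of > 25000 nM in this assay, at which 3 of the 3 values shown sit, the expectation is that the step that the limit leaves unreadable from compound 1 to compound 4 is none beyond the scatter, with compound 4 most likely again reported as a limit. Compound 4 is estimated at 30000 nM, within a range from 15000 nM to 60000 nM.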

Compound 4, half-maximal effective concentration: > 25000 nM
Compound 4 ended at the assay's limit; the forecaster's own chance of this, stated with the estimate: 80%; the middle value lies beyond the limit too.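

Compound 1 and compound 4 are both reported only as limits, so no step between them can be read: the limit of > 25000 nM in this assay, at which 4 of the 4 values shown sit.

The compounds shown leave open how far each lies beyond that limit in this assay, and whether hydrogen in place of fluoro changes anything there.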